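The source may report more compounds than this note shows. Statements on the series, on what has been measured and on what is new or still open speak of the compounds shown alone.

Series notes, step from compound 3 to compound 4.

Three compounds carry measurements in a functional assay on PC-3 cells (Homo sapiens) for cytotoxicity, read by MTT assay, with a stated time of 72 h; on this read-out higher numbers stand for weaker inhibition and lower numbers for stronger inhibition. Compound 1 `O=C(Nc1ccc(Oc2ccnc3[nH]ccc23)cc1)c1nn(-c2ccc(Cl)cc2)ccc1=O` gives 32400 nM. Compound 2 `O=C(Nc1ccc(Oc2ccnc3[nH]ccc23)cc1)c1nn(-c2ccccc2)ccc1=O`, the same core without the chloro group, gives 15000 nM. Compound 3 `O=C(Nc1ccc(Oc2ccnc3[nH]ccc23)c(F)c1)c1nn(-c2ccc(Cl)cc2)ccc1=O` gives 42500 nM; this is the highest of the three numbers, with compound 1 the nearest and compound 2 the furthest from it.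

The two single-point steps among the measured compounds read a 2.2-fold lower number from compound 1 to compound 2 (0.33 log units; beyond the scatter) and a 1.3-fold higher number from compound 1 to compound 3 (0.12 log units; within the scatter). Only the first is beyond the scatter, and it concerns the substituent on the same ring that changes here.

Compound 4 `O=C(Nc1ccc(Oc2ccnc3[nH]ccc23)c(F)c1)c1nn(-c2ccc(Cl)c(C(F)(F)F)c2)ccc1=O` differs from compound 3 by trifluoromethyl in place of hydrogen on an aromatic carbon. Among the compounds with values here, no measured pair covers a trifluoromethyl group anywhere, so the step from compound 1 to compound 2 is the only guide: there, taking the chloro group off that ring lowered the number modestly, and adding a further substituent to the same ring, 4-chlorophenyl to 4-chloro-3-(trifluoromethyl)phenyl, is more likely to leave the number unchanged or move it upward than downward. No step beyond the scatter is expected.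

Compound 4 is therefore expected to give about 45000 nM in this assay, within 16000 nM to 120000 nM, an expected step of a 1.1-fold higher number from compound 3 to compound 4 (0.02 log units; within the scatter).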

Compound 4, half-maximal inhibitory concentration: 5500 nM
Beside the measured number, compound 4's estimate is 8.2-fold (0.91 log units) above it, and the stated range ends above it.
By their numbers in this assay, from the lowest: compound 4; then compound 2; then compounds 1 and 3 (each within the scatter of the next).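

In this assay, the phenyl ring carrying the chloro group can move the number downward when a group is added, not only when one is taken away: trifluoromethyl in place of hydrogen, ortho to a chloro group, gives a 7.7-fold lower number from compound 3 to compound 4 (0.89 log units; beyond the scatter). Within the data shown here, until now the only step beyond the scatter on this ring was the loss of the chloro group, a 2.2-fold lower number from compound 1 to compound 2 (0.33 log units; beyond the scatter), so the two steps together do not support a simple reading in which fewer substituents on this ring give a lower number, and compound 4 goes against that reading. Nothing at hand accounts for the size or direction of the new step.

Going by these compounds, the trifluoromethyl step is read only on compound 3, which carries the fluoro group, so it remains open whether the same drop appears without that fluoro group, even though a 1.3-fold higher number from compound 1 to compound 3 (0.12 log units; within the scatter) lies within the scatter. Also open, on these data alone, are whether the drop needs the chloro group to stay in place, and whether a methyl group, a nitrile or an amine at the same place would give a step of the same kind.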